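Fluoro in place of hydroxy: what size of step?

A few compounds are considered here, and "the series" means these few. Any claim that something is new, unique, unknown or untested is made for them only; others in the source may bear on it.

- compound 1 `C=C1C(=O)[C@]23C[C@@]1(Cl)CC[C@H]2[C@@]12C=CC(=O)[C@](C)(C(=O)O1)[C@H]2[C@@H]3C(=O)OC` measures 4800 nM here
- compound 2 `C=C1C(=O)[C@]23C[C@@]1(O)CC[C@H]2[C@@]12C=CC(=O)[C@](C)(C(=O)O1)[C@H]2[C@@H]3C(=O)OC` measures 39600 nM here

In a functional assay on MKN-28 cells (Homo sapiens) for cytotoxicity, read by MTT assay (on this read-out lower numbers stand for stronger inhibition and higher numbers for weaker inhibition), compound 2 has the higher of the two numbers, which makes it the weaker inhibitor of the pair. Compound 3 `C=C1C(=O)[C@]23C[C@@]1(F)CC[C@H]2[C@@]12C=CC(=O)[C@](C)(C(=O)O1)[C@H]2[C@@H]3C(=O)OC` has not been measured yet. It carries fluoro in place of hydroxy on a saturated ring carbon.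

For the measured compounds named here, only one measured step bears on this change. Swapping chloro for hydroxy on that carbon gave an 8.3-fold higher number from compound 1 to compound 2 (0.92 log units; beyond the scatter) and this is clearly beyond the scatter. Fluoro, like chloro, is a halogen, so a partial return towards compound 1 seems likely, although a single step fixes the size only loosely. The expected change in this assay is a 3.3-fold lower number from compound 2 to compound 3 (0.52 log units; beyond the scatter) in the direction of stronger inhibition. Compound 3 is estimated at 12000 nM (range 4000 nM to 36000 nM).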

Compound 3, half-maximal inhibitory concentration: 4100 nM
Compound 3: the middle estimate sits 2.9-fold (0.47 log units) above what was measured; the range from low to high includes it.
By their numbers in this assay, from the lowest: compounds 3 and 1 (each within the scatter of the next); then compound 2.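

In this assay, fluoro in place of hydroxy gives a 9.7-fold lower number from compound 2 to compound 3 (0.98 log units; beyond the scatter) and so brings the number back to the level of the chloro compound rather than only part of the way. Fluoro in place of chloro gives a 1.2-fold lower number from compound 1 to compound 3 (0.07 log units; within the scatter) and shows that these two halogens cannot be told apart at this carbon, so of the three groups shown, hydroxy alone stands apart. Nothing available explains why hydroxy differs from the two halogens here.

Still open, on these data alone, is whether a group that is neither hydroxy nor a halogen, such as an amine or a methoxy group, would read like hydroxy or like the halogens on this carbon. Bromo, a larger halogen, would show whether the match between fluoro and chloro extends further down that series.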